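The source may report more compounds than this note shows. Statements on the series, on what has been measured and on what is new or still open speak of the compounds shown alone.

Compound 1 `CCCCOc1ccccc1Cc1cnc(N)nc1N`: 8710 nM in an assay for inhibition of Dihydrofolate reductase (Gallus gallus); on this read-out higher numbers stand for weaker inhibition and lower numbers for stronger inhibition
Compound 2 `CCOc1ccccc1Cc1cnc(N)nc1N`: 24500 nM in this assay

Compound 2 has the higher of the two numbers, the gap being a 2.8-fold higher number from compound 1 to compound 2 (0.45 log units; beyond the scatter). Compound 3 `Nc1ncc(Cc2ccccc2Cl)c(N)n1` brings (chloro in place of ethoxy on an aromatic carbon). Among the compounds with values here, the only measured step, from compound 1 to compound 2, shows that shortening the chain on the oxygen raised the number; no step covers an exchange of the whole group for a chlorine. Taking the trend of that step as a rough guide, a further modest rise is expected for compound 3, roughly a 1.4-fold higher number from compound 2 to compound 3 (0.15 log units; within the scatter). Compound 3 is therefore estimated at 35000 nM, within 12000 nM to 100000 nM.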

Compound 3, inhibition constant: 17400 nM
The estimate for compound 3 lay 2.0-fold (0.30 log units) above the measured number, and the stated range covers the measured number.
By their numbers in this assay, from the lowest: compounds 1, 3 and 2 (each within the scatter of the next, the first and the last beyond it).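

Chloro in place of ethoxy on this aromatic carbon gives a 1.4-fold lower number from compound 2 to compound 3 (0.15 log units; within the scatter) in this assay, and chloro in place of butoxy gives a 2.0-fold higher number from compound 1 to compound 3 (0.30 log units; within the scatter) in the same read-out. So a single chlorine, with no oxygen and no chain, cannot be told apart from either of the two chains on oxygen, even though those two chains differ from each other beyond the scatter. Nothing at hand explains this result.

Still open, on these data alone, is how an amine, a carboxylic acid or a chain longer than butoxy would behave on this carbon.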